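The source may hold more compounds than are shown below. What is called first, only, known or untested is meant among the compounds shown, and "the series" means these compounds.

Compound 3 `CCC(=O)NCCCO[C@@H]1[C@@H](C)N(C)C[C@H](C)C[C@@](C)(O)[C@H](O[C@@H]2O[C@H](C)C[C@H](N(C)C)[C@H]2O)[C@@H](C)[C@H](O[C@H]2C[C@@](C)(OC)[C@@H](O)[C@H](C)O2)[C@@H](C)C(=O)O[C@H](CC)[C@@]1(C)O` stands second highest of the three numbers seen so far in a physicochemical assay for lipophilicity, read by HPLC, measured as chromatographic lipophilicity, at pH 7.4 (on this read-out lower numbers stand for lower lipophilicity and higher numbers for higher lipophilicity), where compound 3 gives 2.74. Its nearest neighbour is compound 1 `CC[C@H]1OC(=O)[C@H](C)[C@@H](O[C@H]2C[C@@](C)(OC)[C@@H](O)[C@H](C)O2)[C@H](C)[C@@H](O[C@@H]2O[C@H](C)C[C@H](N(C)C)[C@H]2O)[C@](C)(O)C[C@@H](C)CN(C)[C@H](C)[C@@H](OCCCNC(=O)COC)[C@]1(C)O`, which in this assay gives 2.58; the step of a number 0.16 log units higher from compound 1 to compound 3 (within the scatter) lies within the scatter. The furthest is compound 2 `CCCCC(=O)NCCCO[C@@H]1[C@@H](C)N(C)C[C@H](C)C[C@@](C)(O)[C@H](O[C@@H]2O[C@H](C)C[C@H](N(C)C)[C@H]2O)[C@@H](C)[C@H](O[C@H]2C[C@@](C)(OC)[C@@H](O)[C@H](C)O2)[C@@H](C)C(=O)O[C@H](CC)[C@@]1(C)O`, which gives 3.74, so that a number 1.00 log units lower from compound 2 to compound 3 (beyond the scatter).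

Compound 4 `CCCCCCCC(=O)NCCCO[C@@H]1[C@@H](C)N(C)C[C@H](C)C[C@@](C)(O)[C@H](O[C@@H]2O[C@H](C)C[C@H](N(C)C)[C@H]2O)[C@@H](C)[C@H](O[C@H]2C[C@@](C)(OC)[C@@H](O)[C@H](C)O2)[C@@H](C)C(=O)O[C@H](CC)[C@@]1(C)O` has not yet been measured. It differs from compound 3 in one place: pentyl in place of hydrogen on a saturated chain carbon, two bonds along the chain from a carbonyl carbon. Going by the values given here, two measured steps bear on this. The same place was already varied, since a number 1.00 log units lower from compound 2 to compound 3 (beyond the scatter), and a related lengthening gave a number 1.16 log units higher from compound 1 to compound 2 (beyond the scatter). Compound 4 carries a much longer chain than compound 2 at that place, so a step upward in this assay that is larger than either of those is expected for compound 4, namely a number 2.16 log units higher from compound 3 to compound 4 (beyond the scatter). Compound 4 is therefore estimated to give 4.9 in this assay, expected to fall between 4.3 and 5.6.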

Compound 4, distribution coefficient: 5.18
Compound 4: middle estimate off by 0.28 log units, on the low side, and the stated range covers the measured number.
By their numbers in this assay, from the lowest: compounds 1 and 3 (each within the scatter of the next); then compound 2; then compound 4.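

In this assay, going by these compounds alone, pentyl in place of hydrogen on this saturated chain carbon gives a number 2.44 log units higher from compound 3 to compound 4 (beyond the scatter), a wider spread than the earlier compounds showed at this place. The number has not levelled off at the long end of the series, with a number 1.44 log units higher from compound 2 to compound 4 (beyond the scatter) for propyl in place of hydrogen, so it rises at each lengthening from compound 3 to compound 2 to compound 4, and none of these three goes against that. The change from the methoxy-bearing side chain is larger still, with a number 2.60 log units higher from compound 1 to compound 4 (beyond the scatter) for hexyl in place of methoxy, and nothing shown here accounts for why the number climbs in this way.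

Going by these compounds, whether a still longer chain would keep raising the number remains open. So does what a branched chain, a phenyl ring or an amine would give at this place.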